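This account rests on a few compounds, and the source may have more. Where it says the series, first, only, none or still open, it means among the compounds named here.

In a functional assay on A549 cells (Homo sapiens) for antiproliferative activity, read by MTT assay, with a stated time of 72 h (a lower number here means a stronger inhibitor, a higher number a weaker inhibitor), compound 2, `COc1ncc(-c2ccc3c(c2)NC(=O)CO3)cc1NS(=O)(=O)c1ccc(F)cc1`, gives 8070 nM. Going by the values given here, compound 1, `COc1ncc(-c2ccc3c(c2)N(c2ccc(Cl)cc2)C(=O)CO3)cc1NS(=O)(=O)c1ccc(F)cc1`, gives 8350 nM in this assay, and the two numbers are within the scatter of each other, so compound 2 stands level with the only other measured compound. Compound 3, `COc1cccc(N2C(=O)COc3ccc(-c4cnc(OC)c(NS(=O)(=O)c5ccc(F)cc5)c4)cc32)c1`, has not yet been measured; it differs from compound 2 by 3-methoxyphenyl in place of hydrogen on an amide-type nitrogen in a ring. Among the compounds with values here, only one measured step bears on this change: the step of a 1.0-fold lower number from compound 1 to compound 2 (0.01 log units; within the scatter), which removed an aryl group from the same amide-type nitrogen in a ring. Putting a different aryl group back onto that nitrogen is therefore expected to leave the number close to where compound 2 sits, with no shift beyond the scatter. Compound 3 is accordingly estimated at 8000 nM, with a range from 3500 nM to 18000 nM, meaning an expected step of a 1.0-fold lower number from compound 2 to compound 3 (0.00 log units; within the scatter).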

Compound 3, half-maximal inhibitory concentration: 11200 nM
Beside the measured number, compound 3's estimate is 1.4-fold (0.15 log units) below it; the range from low to high includes it.
By their numbers in this assay, from the lowest: compounds 2, 1 and 3 (each within the scatter of the next).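

In this assay, 3-methoxyphenyl in place of hydrogen on the amide-type nitrogen in a ring gives a 1.4-fold higher number from compound 2 to compound 3 (0.14 log units; within the scatter) and 3-methoxyphenyl in place of 4-chlorophenyl at that nitrogen gives a 1.3-fold higher number from compound 1 to compound 3 (0.13 log units; within the scatter). The earlier pair set only hydrogen against 4-chlorophenyl, whereas compound 3 adds a second aryl group with a different substituent, and all three groups now stand within the scatter of one another at this position. No evidence is available to explain this level reading.

The compounds shown leave open whether a group that is not an aryl ring, such as a short alkyl chain or a chain ending in an amine or a carboxylic acid, would also stand level here. They also leave open whether any group on this nitrogen can move the number beyond the scatter.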